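The source may hold more compounds than are shown below. What is called first, only, known or untested is meant among the compounds shown, and "the series" means these compounds.

The series is a set of thiosemicarbazones tested for tolerance on Vero cells. Compound 1 `S=C(NN=C(c1ccccc1)c1ccccc1)N(Cc1ccccc1)Cc1ccccc1` gives in an ADME assay on Vero cells (Chlorocebus sabaeus) for cytotoxicity, read by MTT assay, with a stated time of 72 h (a lower number here means that less compound is tolerated, a higher number that more compound is tolerated), a value of 143000 nM. For compound 2 `C=CCN(CC=C)C(=S)N/N=C\c1ccccc1O` the result in this assay is "not determined" (no result reported). Compound 3 `C=CCN(CC=C)C(=S)N/N=C(/C)c1ccc(F)cc1` gives in this assay 214000 nM, a number that lies within the scatter of the value of compound 1, so the two are not separable on these data. Compound 4 `C=CCN(CC=C)C(=S)N/N=C(/C)c1ccc(O)cc1` differs from compound 3 only by hydroxy in place of fluoro on an aromatic carbon. Going by the values given here, no measured pair of this kind exists in the set; with hydroxy replacing fluoro at that aromatic carbon, no step beyond the scatter is expected in this assay. Compound 4 is therefore estimated at 200000 nM, with a range from 80000 nM to 500000 nM. The step implied from compound 3 to compound 4 is expected to be a 1.1-fold lower number from compound 3 to compound 4 (0.03 log units; within the scatter).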

Compound 4, half-maximal cytotoxic concentration: 216000 nM
Estimate against measurement, compound 4: 1.1-fold (0.03 log units) below, within the range that was stated.
By their numbers in this assay, from the lowest: compounds 1, 3 and 4 (each within the scatter of the next).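

Going by these compounds alone, this is the first pair that differs in one place: in this assay, hydroxy in place of fluoro on this aromatic carbon gives a 1.0-fold higher number from compound 3 to compound 4 (0.00 log units; within the scatter) and so no separable change. At this position, the hydrogen-bond donor and acceptor that enter with hydroxy leave the result inseparable from that of compound 3. Nothing on hand gives a reason for this result.

As far as these compounds go, whether an amine or a carboxylic acid on this carbon would also stay within the scatter of compound 3 remains open. Also open, from the compounds shown here alone, is whether the same change would behave alike on the core of compound 1.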